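This account rests on a few compounds, and the source may have more. Where it says the series, first, only, none or still open, it means among the compounds named here.

Compound 1 `CC1CCN(C2CCN(S(=O)(=O)c3nccn3C)CC2)CC1`: in a functional assay on DLD-1 cells (Homo sapiens) for antiproliferative activity, read by CellTiter-Glo, with a stated time of 72 h (a lower number here means a stronger inhibitor, a higher number a weaker inhibitor), compound 1 gives > 5000 nM, which is a limit of the assay and not a number.
Compound 2 `Cc1cc(C)c(S(=O)(=O)N2CCC(N3CCN(C)CC3)CC2)c(C)c1`: in this assay compound 2 gives 1100 nM.
Compound 3 `Cc1ccc(C#N)c(S(=O)(=O)N2CCC(N3CCC(C)CC3)CC2)c1`: in this assay compound 3 gives 285 nM.

Of the two numbers in hand, compound 2 holds the higher one; compound 3 shows a lower number, and the gap between the two lies beyond the usual scatter of repeated measurements. The reading for compound 1 is the limit of > 5000 nM in this assay, at which 1 of the 3 values shown sits, so it cannot be placed among the numbers.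

Compound 4 `Cc1cc(C)c(S(=O)(=O)N2CCC(N3CCCCCC3)CC2)c(C)c1` is the next candidate. It differs from compound 2 in one place: azepan-1-yl in place of 4-methylpiperazin-1-yl on a saturated ring carbon. For the measured compounds named here, no measured pair isolates this change. Compounds 1 and 3 carry a different saturated amine on the same carbon, but they also carry different sulfonyl aryl groups, so their values say nothing clean about the amine alone.

The step from compound 2 to compound 4 is therefore expected to be modest, a 1.6-fold lower number from compound 2 to compound 4 (0.20 log units; within the scatter), leaning toward a lower number but not certainly beyond the scatter. Compound 4 is expected to give an estimate of 700 nM in this assay, with a range from 200 nM to 3000 nM.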

Compound 4, half-maximal inhibitory concentration: 5.3 nM
Compound 4: the middle estimate sits 130-fold (2.12 log units) above what was measured; measured number below the stated range.
By their numbers in this assay, from the lowest: compound 4; then compound 3; then compound 2. At a limit, above all of these: compound 1.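

In this assay, azepan-1-yl in place of 4-methylpiperazin-1-yl gives a 210-fold lower number from compound 2 to compound 4 (2.32 log units; beyond the scatter), so the amine on this saturated ring carbon, three ring bonds from the ring nitrogen, can by itself shift the value far beyond the scatter. This is the first pair shown in which the amine is the only difference; compounds 1 and 3 also differ in their sulfonyl aryl groups, and the large step occurs with the heavy-atom count of the group unchanged, while one six-membered ring with 2 hetero atoms gives way to one seven-membered ring with 1 hetero atom. No measurement shown gives a reason for the size of this step.

This single pair leaves open whether the step follows the ring size or the loss of the second ring nitrogen, a question that unsubstituted piperidin-1-yl or 1,4-diazepan-1-yl on the same carbon would bear on. It also leaves open whether azepan-1-yl would have a comparable effect with a different sulfonyl aryl group, such as the nitrile-bearing aryl group of compound 3.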